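The compounds below may be only part of what the source reports. "The series", "measured", "known", "first", "only" and "open" are said of these compounds alone.

Compound 1 `CCn1c(-c2ccc(OCc3c(-c4c(Cl)cccc4Cl)noc3C(C)C)cc2)nc2ccc(C(=O)O)cc21` gives 5760 nM in an assay on HEK-293T cells for antagonist activity at vitamin D3 receptor (Homo sapiens), read by a luciferase reporter, with a stated time of 24 h; on this read-out higher numbers stand for weaker inhibition and lower numbers for stronger inhibition.
Compound 2 `CC(C)c1onc(-c2c(Cl)cccc2Cl)c1COc1ccc(-c2nc3ccc(C(=O)O)cc3n2-c2ccc(F)cc2)cc1` gives 2410 nM in this assay.

Compound 2 holds the lowest of the two numbers in this assay, with compound 1 nearest. Among the compounds with values here, the one measured step, a 2.4-fold lower number from compound 1 to compound 2 (0.38 log units; beyond the scatter), was modest and lies beyond the scatter. Compound 3 `CC(C)c1onc(-c2c(Cl)cccc2Cl)c1COc1ccc(-c2nc3ccc(C(=O)O)cc3n2C2CCCCCC2)cc1` differs from compound 2 by cycloheptyl in place of 4-fluorophenyl on an aromatic nitrogen. Within the data shown here, no measured step replaces one ring group on that nitrogen with another, so the step from compound 2 to compound 3 lacks a direct precedent; the expected step of a 1.2-fold lower number from compound 2 to compound 3 (0.08 log units; within the scatter) is therefore small and within the scatter. Compound 3 is estimated at 2000 nM, between 700 nM and 6000 nM.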

Compound 3, half-maximal inhibitory concentration: 921 nM
The estimate for compound 3 lay 2.2-fold (0.34 log units) above the measured number; low and high end bracket the measured number.
By their numbers in this assay, from the lowest: compound 3; then compound 2; then compound 1.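

On the aromatic nitrogen, cycloheptyl in place of 4-fluorophenyl gave a 2.6-fold lower number from compound 2 to compound 3 (0.42 log units; beyond the scatter) in this assay, so a non-aromatic carbon ring of the same heavy-atom count went further than the aromatic ring. Cycloheptyl in place of ethyl gave a 6.3-fold lower number from compound 1 to compound 3 (0.80 log units; beyond the scatter), the largest step seen at this position. No evidence at hand explains either step.

The compounds shown cannot separate ring size from the loss of aromaticity at this nitrogen. On these data alone, how cyclohexyl, unsubstituted phenyl or a longer chain such as hexyl would compare remains open.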